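This account rests on a few compounds, and the source may have more. Where it says the series, first, only, none or still open, it means among the compounds named here.

Measured in a functional assay on MDA-MB-231 cells (Homo sapiens) for antiproliferative activity, read by MTT assay, with a stated time of 24 h; a higher number here means a weaker inhibitor, a lower number a stronger inhibitor:
- compound 1 `O=C(O)CC(NS(=O)(=O)c1ccccc1)c1ccccc1`: > 100000 nM (a limit of the assay, not a number)
- compound 2 `N#Cc1ccc(S(=O)(=O)NC(CC(=O)O)c2ccccc2)cc1`: 48700 nM
- compound 3 `O=C(O)CC(NS(=O)(=O)c1ccc(C(F)(F)F)cc1)c1ccccc1`: 56100 nM

Compound 3 cannot be told apart from compound 2, since a 1.2-fold higher number from compound 2 to compound 3 (0.06 log units; within the scatter). Compound 4 `O=C(O)CC(NS(=O)(=O)c1ccc(OC(F)(F)F)cc1)c1ccccc1` carries trifluoromethoxy in place of trifluoromethyl on an aromatic carbon, para to a large group (trifluoromethoxy in place of trifluoromethyl on an aromatic carbon). The steps that replaced hydrogen on an aromatic carbon were small: an at least 2.0-fold lower number from compound 1 to compound 2 (0.31 log units; beyond the scatter) and an at least 1.7-fold lower number from compound 1 to compound 3 (0.25 log units; that floor lies within the scatter). The closest guide is the exchange of one group for another, a 1.2-fold higher number from compound 2 to compound 3 (0.06 log units; within the scatter). No step beyond the scatter is therefore expected in this assay, and the expected step is a 1.0-fold lower number from compound 3 to compound 4 (0.01 log units; within the scatter). For compound 4 the estimated value is 55000 nM, with an expected range of 27000 nM to 100000 nM.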

Compound 4, half-maximal inhibitory concentration: > 100000 nM
Compound 4: only a limit was reported; the forecaster's own chance of this, stated with the estimate: 15%; middle value at least 1.8-fold (0.25 log units) away from the limit.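

In this assay compound 4 gives only a limit, not a number. Even so, trifluoromethoxy at this aromatic carbon, para to a large group, parts from cyano, with an at least 2.0-fold higher number from compound 2 to compound 4 (0.31 log units; beyond the scatter), whereas the comparison with trifluoromethyl stays unsettled, with an at least 1.7-fold higher number from compound 3 to compound 4 (0.25 log units; that floor lies within the scatter). The step between the other two compounds cannot be read, and the ceiling now holds compound 1 as well as compound 4: the limit of > 100000 nM in this assay, at which 2 of the 4 values shown sit.

As far as these compounds go, the true size of these steps remains open, as does whether trifluoromethoxy differs from hydrogen here. From the compounds shown here alone, how an amine or a carboxylic acid on this carbon would read is also open.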